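Chloro substitution on a weakly cytotoxic core

The source may hold more compounds than are shown below. What is called first, only, known or untested is meant among the compounds shown, and "the series" means these compounds.

Compound 1 `CCn1c(/C=C2/C(=O)Nc3ccccc32)nc2ccccc21` gives > 50000 nM in a functional assay on HGC cells (Homo sapiens) for cytotoxicity, read by MTT assay, with a stated time of 48 h (on this read-out higher numbers stand for weaker inhibition and lower numbers for stronger inhibition), which is a limit of the assay and not a number.
Compound 2 `Cn1c(/C=C2/C(=O)Nc3ccc(Br)cc32)nc2ccccc21` gives > 50000 nM, again a limit.
Compound 3 `Cn1c(/C=C2/C(=O)Nc3ccc(F)cc32)nc2ccccc21` gives 37800 nM.

Compound 1 therefore stands at the limit of > 50000 nM in this assay, at which 2 of the 3 values shown sit; no finite number is known for it. Compound 4 `CCn1c(/C=C2/C(=O)Nc3ccc(Cl)cc32)nc2ccccc21` is derived from compound 1 by chloro in place of hydrogen on an aromatic carbon. Among the measured compounds shown here, the one measured step, an at least 1.3-fold lower number from compound 2 to compound 3 (0.12 log units; that floor lies within the scatter), exchanges one halogen for another within the methyl series and so bears only loosely on a change from hydrogen to chloro in the ethyl series; its size is itself within the scatter, and its direction is only a floor. For the measured compounds named here, nothing among the measured compounds shows a halogen on this ring carrying a compound clearly away from the limit. The expected step in this assay from compound 1 to compound 4 is therefore a number no higher from compound 1 to compound 4 (the limit leaves the size open), that is, none beyond the scatter. Compound 4 is estimated at 50000 nM, with a range from 20000 nM to 120000 nM, and a further limit is considered likely.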

Compound 4, half-maximal inhibitory concentration: > 50000 nM
Compound 4: no number, only a limit; the forecaster's own chance of this, stated with the estimate: 60%; the middle value lies on the limit itself.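

Compound 1 and compound 4 both rest on a limit of the assay and not on a number, so no step can be read between them: the limit of > 50000 nM in this assay, at which 3 of the 4 values shown sit. The compounds shown leave open whether chloro in place of hydrogen on an aromatic carbon changes the cytotoxicity at all, and by how much.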